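The source may report more compounds than this note shows. Statements on the series, on what has been measured and on what is new or still open speak of the compounds shown alone.

Compound 3 `O=C(O)[C@@H]1NC[C@@H](O)[C@H](O)[C@@H]1O` gives 0.8% in an assay on isolated protein for inhibition of cytosolic endo-beta-N-acetylglucosaminidase (Homo sapiens), tested at 1000 uM (a higher number here means more inhibition at the concentration tested (going by the name of the read-out), a lower number less inhibition), and stands lowest of the three numbers measured. Compound 2 `O=C(O)[C@H]1NCC=C[C@H]1O` gives 17% in this assay, and compound 1 `O=C(O)[C@H]1NCC=C[C@@H]1O` gives 60%. Compound 4 `O=C(O)[C@@H]1NC[C@H](O)[C@@H](O)[C@@H]1O` has not yet been measured; it differs from compound 3 in this way: the two compounds have the same atoms and bonds and differ only in configuration as drawn: 2 of 4 stereo elements differ; a stereocentre at a saturated ring carbon is drawn R in compound 3 and S in compound 4; a stereocentre at a saturated ring carbon is drawn S in compound 3 and R in compound 4. Going by the values given here, one measured step bears on such a change: a number 43 percentage points lower from compound 1 to compound 2 (beyond the scatter), a large drop which, because of the fact that compounds 1 and 2 differ only in the configuration as drawn, shows that turning one ring stereocentre alone can move inhibition strongly. Compound 3 sits close to no inhibition, so any step beyond the scatter here can only go upward, though its size stays uncertain. Compound 4 is therefore expected to show a number 14.2 percentage points higher from compound 3 to compound 4 (beyond the scatter), and its inhibition is estimated at 15%, within a range from 0% to 55%.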

Compound 4, a percentage reported as inhibition, at one concentration (the size of the read-out at that concentration, not a potency): 5.4%
Compound 4: middle estimate off by 9.6 percentage points, on the high side, within the range that was stated.
By their numbers in this assay, from the lowest: compounds 3 and 4 (each within the scatter of the next); then compound 2; then compound 1.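

In this assay the result is a number 4.6 percentage points higher from compound 3 to compound 4 (within the scatter), so changing these two ring stereocentres together gives no difference that can be read. Stereochemistry therefore does not always move this read-out, unlike a number 43 percentage points lower from compound 1 to compound 2 (beyond the scatter), though compounds 3 and 4 both sit near no inhibition, where little room remains for a drop. The comparison isolates stereochemistry alone: the fact that compounds 3 and 4 differ only in the configuration as drawn

Going by these compounds, the effect of turning either stereocentre alone remains open. So does whether a methyl ester in place of the carboxylic acid would alter inhibition on this core.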